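A few compounds are considered here, and "the series" means these few. Any claim that something is new, unique, unknown or untested is made for them only; others in the source may bear on it.

Measured compounds in a functional assay on cells for agonist activity at D(4) dopamine receptor (Homo sapiens), read by TR-FRET and cAMP accumulation, with a stated time of 30 min; on this read-out lower numbers stand for smaller maximal responses and higher numbers for larger maximal responses:
- compound 1 `CCc1cccc(NC(=O)CN2CCN(c3ccc(Cl)cn3)CC2)c1` gives "not active" (no number reported)
- compound 2 `Cc1cccc(NC(=O)CCN2CCN(c3ncccn3)CC2)c1` gives 13.7%
- compound 3 `Cc1cccc(NC(=O)CN2CCN(c3ncccn3)CC2)c1` gives 64.6%

Compound 3 stands highest of the two numbers, with compound 2 well below it, beyond the scatter, and compound 1 reported without a number. Compound 4 `Cc1cccc(NC(=O)CN2CCN(c3ccc(Cl)cn3)CC2)c1` is not yet measured. It differs from compound 3 by 5-chloropyridin-2-yl in place of pyrimidin-2-yl on an amine nitrogen in a ring. Going by the values given here, no measured pair shows this exact exchange. Compound 1, which also carries the 5-chloropyridin-2-yl group, gives only "not active" (no number reported) in this assay. A drop beyond the scatter is therefore expected, and the step is estimated as a number 39.6 percentage points lower from compound 3 to compound 4 (beyond the scatter). Compound 4 is expected to reach about 25%, between 5% and 55%.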

Compound 4, largest response reached (Emax), in percent of the reference or control that the assay uses: "not active" (no number reported)
Compound 4 has no reported number here; there is nothing to compare the estimate with.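

Going by these compounds alone, compound 4 has no number, so no step from compound 3 to compound 4 can be read. How much the 5-chloropyridin-2-yl exchange changes the maximal response stays open, and nothing shown offers an explanation.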